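Furan for thiophene on the shared core

The compounds below may be only part of what the source reports. "The series", "measured", "known", "first", "only" and "open" are said of these compounds alone.

Compound 1 `Oc1ccc(-c2cc(-c3cccs3)nc(-c3ccccc3Cl)c2)cc1` gives 4190 nM in a functional assay on DU-145 cells (Homo sapiens) for cytotoxicity, read by CCK-8 assay and cell counting, with a stated time of 2 days; on this read-out lower numbers stand for stronger inhibition and higher numbers for weaker inhibition.
Compound 2 `Oc1ccc(-c2cc(-c3ccc(Cl)cc3)nc(-c3cccs3)c2)cc1` gives 7660 nM in this assay.

On these two numbers compound 2 and compound 1 lie within the scatter of each other, the step being a 1.8-fold higher number from compound 1 to compound 2 (0.26 log units; within the scatter). Compound 3 `Oc1ccc(-c2cc(-c3ccc(Cl)cc3)nc(-c3ccco3)c2)cc1` is not yet measured. It differs from compound 2 by furan-2-yl in place of thiophen-2-yl on an aromatic carbon. Going by the values given here, no measured step touches this exchange: the one step that is known, from compound 1 to compound 2, moves the 4-chlorophenyl group and not the five-membered ring, so it gives no direct guide. Among the compounds with values here, with nothing pointing either way, and with the only known change on this core having stayed within the scatter, compound 3 is expected to sit close to compound 2, the expected step being a 1.0-fold higher number from compound 2 to compound 3 (0.02 log units; within the scatter). Compound 3 is therefore estimated at 8000 nM in this assay, with a range from 3500 nM to 20000 nM.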

Compound 3, half-maximal inhibitory concentration: 7280 nM
Beside the measured number, compound 3's estimate is 1.1-fold (0.04 log units) above it; measured number inside the range.
By their numbers in this assay, from the lowest: compounds 1, 3 and 2 (each within the scatter of the next).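

Going by these compounds alone, compound 3 gives the first reading on the five-membered ring itself, as the earlier step concerned only the chlorophenyl group. In this assay, furan-2-yl in place of thiophen-2-yl on the aromatic carbon next to the ring nitrogen gives a 1.1-fold lower number from compound 2 to compound 3 (0.02 log units; within the scatter), so with a 4-chlorophenyl group on the shared core this read-out does not separate the two rings. No measurement is available that would explain this result.

The compounds shown leave open whether a saturated ring such as cyclohexyl, a plain phenyl or an amine at this position would stay in the same range. They also leave open whether the exchange of thiophen-2-yl for furan-2-yl would read the same way on the core of compound 1, which carries a 2-chlorophenyl group.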